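From naphthalen-1-yl to 4-methylphenyl: a single swap

The source may hold more compounds than are shown below. What is called first, only, known or untested is meant among the compounds shown, and "the series" means these compounds.

For the measured compounds named here, in a functional assay on MCF7 cells (Homo sapiens) for inhibition, read by MTT assay, with a stated time of 72 h (on this read-out higher numbers stand for weaker inhibition and lower numbers for stronger inhibition), compound 1 `O=C(O)CCCCCCC(=O)Nc1ccc(C2=C(c3ccc(O)cc3)C3CC(S(=O)(=O)Oc4cccc5ccccc45)C2O3)cc1` gives 4700 nM, the lowest of the three numbers measured so far. Compound 2 `COC(=O)CCCCCCC(=O)Nc1cccc(OS(=O)(=O)C2CC3OC2C(c2ccc(O)cc2)=C3c2ccc(O)cc2)c1` gives 19100 nM, and compound 3 `O=C(CCCCCCC(=O)Nc1ccc(C2=C(c3ccc(O)cc3)C3CC(S(=O)(=O)Oc4ccccc4)C2O3)cc1)NO` gives 30100 nM. Both of these numbers lie above that of compound 1, by more than the usual scatter between repeated measurements.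

Compound 4 `Cc1ccc(OS(=O)(=O)C2CC3OC2C(c2ccc(NC(=O)CCCCCCC(=O)O)cc2)=C3c2ccc(O)cc2)cc1` has not yet been measured. It keeps the core of compound 1 but carries 4-methylphenyl in place of naphthalen-1-yl on an oxygen. Going by the values given here, no measured pair of compounds differs by this change alone, so the data give no direct size for it.

Among the compounds with values here, the only guide is indirect. Within the data shown here, compound 1, at 4700 nM, is the only measured compound with the naphthalen-1-yl group. Compound 2 and compound 3 lack that group and show higher numbers, but they also differ from compound 1 in other places. A modest move towards weaker inhibition in this assay is therefore expected, not a large one. The estimated change is a 2.1-fold higher number from compound 1 to compound 4 (0.33 log units; beyond the scatter). For compound 4, the expected value is 10000 nM, with an estimated range from 3500 nM to 28000 nM.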

Compound 4, half-maximal inhibitory concentration: 60500 nM
Estimate against measurement, compound 4: 6.1-fold (0.78 log units) below; the measured number lies above the stated range.
By their numbers in this assay, from the lowest: compound 1; then compounds 2, 3 and 4 (each within the scatter of the next, the first and the last beyond it).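

In this assay, the group on the oxygen bound to the sulfonyl sulfur proves to matter a great deal: putting 4-methylphenyl in place of naphthalen-1-yl gives a 13-fold higher number from compound 1 to compound 4 (1.11 log units; beyond the scatter) and provides the first directly measured size for a single change at this place. The swap replaces two six-membered aromatic rings of carbon only with one such ring and goes from 10 heavy atoms to 7, while neither group carries a hydrogen-bond donor, a hydrogen-bond acceptor or a net charge, so the large step is tied to a change between two purely carbon groups. No measurement of any property of these groups is available to explain why the step is so large.

This single step cannot separate the loss of the second aromatic ring from the arrival of the methyl group, since both happen in the same swap. The compounds shown also leave open how naphthalen-2-yl or 4-chlorophenyl would behave on this oxygen with the rest of compound 1 unchanged.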